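The compounds below may be only part of what the source reports. "The series", "measured", "known", "first", "only" and "open" are said of these compounds alone.

Working notes on the series. In a functional assay on HL-60 cells (Homo sapiens) for inhibition, read by CCK-8 assay, with a stated time of 48 h (a lower number here means a stronger inhibitor, a higher number a weaker inhibitor), compound 3 (`COc1ccc(Cc2nnc(NC(=O)/C(C#N)=C/c3ccccc3OS(=O)(=O)c3ccc(OC)cc3)s2)cc1`) gives 3120 nM. Compound 2 (`COc1ccc(S(=O)(=O)Oc2ccccc2/C=C(\C#N)C(=O)Nc2nnc(-c3cccs3)s2)cc1`) gives 5230 nM, within the scatter of compound 3. Compound 1 (`Cc1ccc(S(=O)(=O)Oc2ccccc2/C=C(\C#N)C(=O)Nc2nnc(C)s2)cc1`) gives 11500 nM, a clearly higher number than that of compound 3.

Compound 4 (`COc1ccc(Cc2nnc(NC(=O)/C(C#N)=C/c3ccccc3OS(=O)(=O)c3ccc([N+](=O)[O-])cc3)s2)cc1`) carries nitro in place of methoxy on an aromatic carbon, para to a large group, which turns (4-methoxyphenyl)sulfonyl into (4-nitrophenyl)sulfonyl: nitro in place of methoxy on an aromatic carbon.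

Within the data shown here, no measured compound carries nitro, and no measured step changes this place alone. Among the measured compounds shown here, the only single-place step, a 1.7-fold lower number from compound 2 to compound 3 (0.22 log units; within the scatter), swaps thiophen-2-yl for 4-methoxybenzyl, lies within the scatter and gives no direct guide to this change. With no direction supported by the data, the expected step is a 1.0-fold lower number from compound 3 to compound 4 (0.02 log units; within the scatter), which means no change beyond the scatter in this assay, though with real uncertainty. Compound 4 is estimated at 3000 nM, with an expected range of 1200 nM to 7500 nM.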

Compound 4, half-maximal inhibitory concentration: 10900 nM
Compound 4: middle estimate off by 3.6-fold (0.56 log units), on the low side; measured number outside the range, above it.
By their numbers in this assay, from the lowest: compounds 3 and 2 (each within the scatter of the next); then compounds 4 and 1 (each within the scatter of the next).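

In this assay, this place on the sulfonyl-bearing ring responds to substitution: a 3.5-fold higher number from compound 3 to compound 4 (0.54 log units; beyond the scatter), a weakening on going from methoxy to nitro. Among these compounds, this is the first single-place change to lie beyond the scatter, and the first to read this place alone, since the only earlier single-place step, a 1.7-fold lower number from compound 2 to compound 3 (0.22 log units; within the scatter), concerned the other end of the molecule and lay within the scatter. Nothing in hand accounts for the size or direction of this step.

From the compounds shown here alone, with only methoxy and nitro compared directly at this place, a single step cannot define a trend, and what an amine or a carboxylic acid on this carbon would give remains open. Also open, going by these compounds, is whether the same change would have a similar effect with thiophen-2-yl in place of 4-methoxybenzyl.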